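This account rests on a few compounds, and the source may have more. Where it says the series, first, only, none or still open, it means among the compounds named here.

In a toxicity assay on Huh-7.5 cells (Homo sapiens) for cytotoxicity, read by MTT assay, with a stated time of 96 h (a higher number here means that more compound is tolerated, a lower number that less compound is tolerated), compound 1 `CN(C)CCN(C)c1ccc(C#N)c(CN2CCN(C(c3ccccc3)c3ccccc3)CC2)c1` gives > 20000 nM, which is a limit and not a number. Compound 2 `N#Cc1ccc(NCCCn2ccnc2)cc1CN1CCN(C(c2ccccc2)c2ccccc2)CC1` gives > 20000 nM, also a limit. Compound 3 `CN(C)CCN(C)c1ccc(C#N)c(CN2CCN([C@H](c3ccccc3)c3ccc(Cl)cc3)CC2)c1` differs from compound 1 by chloro in place of hydrogen on an aromatic carbon. Among the compounds with values here, the only measured step, a step that the two limits leave unreadable from compound 1 to compound 2, concerns a different group and has no readable size. Within the data shown here, the series so far offers only (the limit of > 20000 nM in this assay, at which 2 of the 2 values shown sit). No step beyond the scatter is therefore expected in this assay. The expected step is a number no higher from compound 1 to compound 3 (the limit leaves the size open). Compound 3 is estimated at 20000 nM, with an expected range of 9000 nM to 40000 nM.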

Compound 3, half-maximal cytotoxic concentration: 8230 nM
Estimate against measurement, compound 3: 2.4-fold (0.39 log units) above, outside the stated range (below it).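

In this assay, chloro in place of hydrogen on an aromatic carbon, para to a large group, gives an at least 2.4-fold lower number from compound 1 to compound 3 (0.38 log units; beyond the scatter), so a change at this position can move the read-out. Compound 3 is the first in the series with a number and not a limit: the limit of > 20000 nM in this assay, at which 2 of the 3 values shown sit.

On these data alone, the full size of the step stays open, as compound 1 stands at a limit. Also open, as far as these compounds go, is whether fluoro, bromo or methoxy at the same place would act as chloro does, and whether chloro would give a similar step on compound 2.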